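The source may hold more compounds than are shown below. What is called first, only, known or untested is meant among the compounds shown, and "the series" means these compounds.

Measured compounds:
compound 1, `COc1ccccc1-c1nnc(Nc2ccc(C)cc2)s1`, which in an assay on isolated protein for inhibition of beta-glucuronidase (Bos taurus), read by spectrophotometry, with a stated time of 30 min (a higher number here means a weaker inhibitor, a lower number a stronger inhibitor), gives 58100 nM
compound 2, `COc1ccc(-c2nnc(Nc3ccc(Cl)c(Cl)c3)s2)cc1`, which in this assay gives 4160 nM

Of the two numbers shown, compound 2 holds the lowest; its nearest neighbour, compound 1, sits at a higher value, and that gap lies beyond the usual scatter. Compound 3, `Clc1ccc(Nc2nnc(-c3ccc(Br)cc3)s2)cc1Cl`, is the next to be measured in this assay. Set against compound 2, it carries bromo in place of methoxy on an aromatic carbon. Going by the values given here, no step between two measured compounds speaks to this change, so the only anchor is the value of compound 2 in this assay, 4160 nM. On that footing a modest step is expected, likely within the scatter or only slightly beyond it, in either direction, with no strong reason to lean one way. The step the estimate implies is a 1.2-fold lower number from compound 2 to compound 3 (0.08 log units; within the scatter), stated as an expectation. Compound 3 is thus expected to give 3500 nM in this assay, within a range from 1200 nM to 10000 nM.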

Compound 3, half-maximal inhibitory concentration: 7160 nM
Compound 3: the middle estimate sits 2.0-fold (0.31 log units) below what was measured, within the range that was stated.
By their numbers in this assay, from the lowest: compounds 2 and 3 (each within the scatter of the next); then compound 1.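

In this assay, the exchange of methoxy for bromo on an aromatic carbon, para to a large group, reads as a 1.7-fold higher number from compound 2 to compound 3 (0.24 log units; within the scatter), so compound 2 and compound 3 cannot be told apart at this position. Going by these compounds alone, this change removes a hydrogen-bond acceptor and one heavy atom from the group at this position, yet the step does not pass the usual scatter, which the earlier compounds, differing in more than one place, could not show. Nothing measured here offers an explanation for this result.

The compounds shown leave open whether an amine, a hydroxyl or a carboxylic acid at this position would stay within the scatter of compound 2. They also leave open whether the same exchange reads alike on a core without the two chloro groups shared by compound 2 and compound 3.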